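This account rests on a few compounds, and the source may have more. Where it says the series, first, only, none or still open, it means among the compounds named here.

Measured in a functional assay on SF-268 cells (Homo sapiens) for inhibition, read by sulforhodamine B assay, with a stated time of 48 h; a lower number here means a stronger inhibitor of growth, a higher number a weaker inhibitor of growth:
- compound 1 `N#CCC(=O)N/N=C(/CBr)c1ccc(Br)cc1`: 12800 nM
- compound 2 `N#CCC1=C(C#N)CC(c2ccc(Br)cc2)=C(CC(=O)c2ccc(Br)cc2)O1`: 8200 nM
- compound 3 `N#CCC1=C(C#N)CC(c2ccc([N+](=O)[O-])cc2)=C(CC(=O)c2ccc([N+](=O)[O-])cc2)O1`: 5 nM

Compound 3 holds the lowest of the three numbers, and its distance to both compound 2 and compound 1 lies well beyond the scatter. Compound 4 `N#CCC1=C(C#N)CC(c2ccc([N+](=O)[O-])cc2)=C(CC(=O)c2ccc(Br)cc2)O1` is the next one to read: one of the two nitro groups of compound 3 is replaced, bromo in place of nitro on an aromatic carbon, leaving one 4-nitrophenyl and one 4-bromophenyl (bromo in place of nitro on an aromatic carbon).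

No measured pair differs in one place only, so the size of this step is not directly shown. The nearest guide is compound 2 at 8200 nM, which carries 4-bromophenyl in both places where compound 3 has 4-nitrophenyl. With only one of the two replaced, a rise beyond the scatter is expected, smaller than the whole gap to compound 2. The expected change is a 40-fold higher number from compound 3 to compound 4 (1.60 log units; beyond the scatter). For compound 4 the estimated value is 200 nM, with an expected range of 10 nM to 6000 nM.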

Compound 4, concentration for 50% growth inhibition: 2800 nM
Compound 4: the middle estimate sits 14-fold (1.15 log units) below what was measured; measured number inside the range.
By their numbers in this assay, from the lowest: compound 3; then compound 4; then compounds 2 and 1 (each within the scatter of the next).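

In this assay, the two nitro groups of compound 3 no longer count as equal: replacing the one on the aromatic ring attached to the carbonyl gives a large step, a 560-fold higher number from compound 3 to compound 4 (2.75 log units; beyond the scatter), and this single change accounts for most of the distance to the dibromo compound 2. At the other 4-bromophenyl place, nitro in place of bromo gives only a modest step, a 2.9-fold lower number from compound 2 to compound 4 (0.47 log units; beyond the scatter), so the same exchange has a very different size in these two places, although each step is read with a different group in the other place. No measurement on hand explains the size of either step.

On these data alone, whether an amine, a carboxylic acid or a methoxy group on that aromatic carbon could hold the low number of compound 3 remains open. Also open, as far as these compounds go, is how the reversed pairing would read, with 4-nitrophenyl on the carbonyl side and 4-bromophenyl at the other place.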